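Thiourea cytotoxicity: a fluoro-for-chloro swap

This account rests on a few compounds, and the source may have more. Where it says the series, first, only, none or still open, it means among the compounds named here.

Measured so far:
Compound 1 `O=C(NC(=S)Nc1cccc(C(F)(F)F)c1)c1ccccc1`: > 100000 nM
Compound 2 `FC(F)(F)c1cccc(NC(=S)Nc2ccc(Cl)cc2)c1`: 17000 nM
Compound 3 `CCCCc1ccc(NC(=S)Nc2cccc(C(F)(F)F)c2)c(C)c1`: 10000 nM

In an ADME assay on MDBK cells (Bos taurus) for cytotoxicity, read by MTT assay, with a stated time of 96 h (on this read-out lower numbers stand for higher toxicity in this test and higher numbers for lower toxicity in this test), compound 1 reaches only the limit (the limit of > 100000 nM in this assay, at which 1 of the 3 values shown sits), not a number. Compound 2 and compound 3 sit within the scatter of each other, so no order between them can be read from these two numbers. Compound 4 `Fc1cccc(NC(=S)Nc2cccc(C(F)(F)F)c2)c1` has not yet been measured in this assay. It differs from compound 2 by 3-fluorophenyl in place of 4-chlorophenyl on an amide-type nitrogen. Among the compounds with values here, no measured pair shares this change, so the size of the step is open; a small shift toward lower toxicity, not clearly beyond the scatter, is the expectation. Compound 4 is therefore expected to give about 30000 nM, between 10000 nM and 100000 nM, an estimated step of a 1.8-fold higher number from compound 2 to compound 4 (0.25 log units; within the scatter).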

Compound 4, half-maximal cytotoxic concentration: 10000 nM
The estimate for compound 4 lay 3.0-fold (0.48 log units) above the measured number, and the stated range covers the measured number.
By their numbers in this assay, from the lowest: compounds 3, 4 and 2 (each within the scatter of the next). At a limit, above all of these: compound 1.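

Placing 3-fluorophenyl where 4-chlorophenyl stood on the amide-type nitrogen gives a 1.7-fold lower number from compound 2 to compound 4 (0.23 log units; within the scatter) in this assay, so compound 2 and compound 4 cannot be told apart. Within the data shown here, this is the first comparison here between compounds that differ in one place, and it shows that this position can take a different halogen-bearing phenyl group without a readable step. Nothing shown here bears on the reason for this result.

As far as these compounds go, it remains open whether the identity of the halogen or its ring position matters on its own. Also open, from the compounds shown here alone, is how 3-chlorophenyl, or a phenyl group carrying an amine or a carboxylic acid, would read on this nitrogen.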